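This account rests on a few compounds, and the source may have more. Where it says the series, first, only, none or still open, it means among the compounds named here.

Going by the values given here, in a functional assay (Hippocampus) with Rattus norvegicus as the target (on this read-out higher numbers stand for higher potency (the scale is a negative logarithm) and lower numbers for lower potency), compound 2 `COC(=O)[C@@H]1C[C@H]2CN[C@@H]1C2` gives 6, the only actual number so far. Compound 1 `COC(=O)[C@H]1C[C@H]2C[C@@H]1N(C)C2` is reported only as a limit of the assay, < 4. The next compound, compound 3 `COC(=O)[C@H]1C[C@@H]2CN[C@H]1C2`, has the same atoms and bonds as compound 2, and the two are mirror images: the two compounds have the same atoms and bonds and differ only in configuration as drawn: 3 of 3 stereo elements differ (all stereocentres are inverted: mirror images); a stereocentre at a saturated ring carbon is drawn R in compound 2 and S in compound 3; a stereocentre at a saturated ring carbon is drawn R in compound 2 and S in compound 3; a stereocentre at a saturated ring carbon is drawn R in compound 2 and S in compound 3. Among the compounds with values here, no measured pair shows what such an inversion does, so this is a judgement call: a clear loss of potency in this assay is expected from compound 2 at 6. The expected change is a number 1.20 log units lower from compound 2 to compound 3 (beyond the scatter). For compound 3 the estimated value is 4.8, with an expected range of 4 to 6.2.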

Compound 3, negative logarithm of the half-maximal effective concentration: < 4
Compound 3 ended at the assay's limit (the forecaster's own chance of this, stated with the estimate: 35%); at least 0.80 log units between middle value and limit.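

In this assay, inverting all three stereocentres, with no other change, gives a number at least 2.00 log units lower from compound 2 to compound 3 (beyond the scatter). This loss comes from the configuration alone: the fact that compounds 2 and 3 differ only in the configuration as drawn Compound 3 gives < 4, which is a limit of the assay and not a number.

The step from compound 1 to compound 3 cannot be read, which leaves open what methyl on the amine nitrogen does. On these data alone, whether the potency of compound 2 survives a carboxylic acid in place of its methyl ester also remains open.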